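Replacing a Chlorophenyl Amide with a Chloropyridyl Amide

The source may hold more compounds than are shown below. What is called first, only, known or untested is meant among the compounds shown, and "the series" means these compounds.

Compound 1 `O=C(Nc1cccc(-c2oc3cc(-c4ccc(F)cc4)ccc3c(=O)c2O)c1)c1ccc(Cl)cc1`: 3670 nM
Compound 2 `Cc1ccccc1C(=O)Nc1cccc(-c2oc3cc(-c4ccc(F)cc4)ccc3c(=O)c2O)c1`: 11900 nM
Compound 3 `Cc1cc(C)cc(C(=O)Nc2cccc(-c3oc4cc(-c5ccc(F)cc5)ccc4c(=O)c3O)c2)c1`: 5540 nM

Three amides sharing the core of compound 1 have been measured in a functional assay on HeLa cells (Homo sapiens) for antiproliferative activity, read by CCK-8 assay, with a stated time of 72 h; a higher number here means a weaker inhibitor, a lower number a stronger inhibitor. Compound 1 gives the lowest number of the three, though its gap to compound 3 is within the scatter, so no order between those two can be claimed; compound 2 is the furthest from it, as a 3.2-fold higher number from compound 1 to compound 2 (0.51 log units; beyond the scatter) shows. The other steps are a 1.5-fold higher number from compound 1 to compound 3 (0.18 log units; within the scatter) and a 2.1-fold lower number from compound 2 to compound 3 (0.33 log units; beyond the scatter).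

Compound 4 `O=C(Nc1cccc(-c2oc3cc(-c4ccc(F)cc4)ccc3c(=O)c2O)c1)c1ccc(Cl)nc1` has not yet been measured. The change from compound 1 is 6-chloropyridin-3-yl in place of 4-chlorophenyl on a carbonyl carbon. Among the compounds with values here, none of the measured steps is of this kind: each of them exchanges one substituted phenyl for another on the carbonyl carbon, whereas here the ring itself gains a nitrogen while the chlorine stays. The measured steps do show that changes at this position move the result by modest amounts at most, with the largest being from compound 1 to compound 2. Compound 4 is therefore expected to sit close to compound 1, with a step estimated at a 1.2-fold higher number from compound 1 to compound 4 (0.09 log units; within the scatter), not clearly beyond the scatter in either direction. The estimate for compound 4 in this assay is 4500 nM, with a range from 2000 nM to 10000 nM.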

Compound 4, half-maximal inhibitory concentration: 4080 nM
Beside the measured number, compound 4's estimate is 1.1-fold (0.04 log units) above it, and the stated range covers the measured number.
By their numbers in this assay, from the lowest: compounds 1, 4 and 3 (each within the scatter of the next); then compound 2.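

In this assay, within the data shown here, the earlier compounds only exchanged one substituted phenyl for another on the carbonyl carbon, whereas this pair shows that 6-chloropyridin-3-yl can stand in place of 4-chlorophenyl with no readable change (a 1.1-fold higher number from compound 1 to compound 4 (0.05 log units; within the scatter)). The new amide also cannot be told apart from the 3,5-dimethylphenyl amide (a 1.4-fold lower number from compound 3 to compound 4 (0.13 log units; within the scatter)), but it keeps a modest gap beyond the scatter to the 2-methylphenyl amide (a 2.9-fold lower number from compound 2 to compound 4 (0.46 log units; beyond the scatter)), so compound 2 remains the weakest of the four and the only one set apart from all the others. Nothing available accounts for this outcome.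

The compounds shown leave open whether the result would hold with an amine or a methoxy group in place of the chlorine on the 6-chloropyridin-3-yl ring. They also do not show what a saturated ring such as piperidine, or a longer chain, would do on the same carbonyl carbon.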